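The source may hold more compounds than are shown below. What is called first, only, known or untested is meant among the compounds shown, and "the series" means these compounds.

Measured so far in a physicochemical assay for lipophilicity, read by HPLC, measured as octanol-water partition (a lower number here means a more polar compound, a higher number a more lipophilic compound), are three compounds:

- compound 1 `O=C1O[C@@H](CO)CN1c1ccc(-n2cc(-c3ccccn3)cn2)c(F)c1` gives 1.67
- compound 2 `O=C1O[C@@H](CN2CCC(O)CC2)CN1c1ccc(-n2cc(-c3ccccn3)cn2)c(F)c1` gives 1.63
- compound 3 `O=C1O[C@@H](CN2CCC(c3ccc(F)cc3)CC2)CN1c1ccc(-n2cc(-c3ccccn3)cn2)c(F)c1` gives 5.78

Compound 2 (1.63) stands level with compound 1 at the low end of these numbers, and the distance to the top is large (a number 4.15 log units higher from compound 2 to compound 3 (beyond the scatter)). Compound 4 `COC[C@H]1CN(c2ccc(-n3cc(-c4ccccn4)cn3)c(F)c2)C(=O)O1` has not yet been measured. Its structure differs from that of compound 2 by one change (methoxy in place of 4-hydroxypiperidin-1-yl on a saturated chain carbon bound to a saturated ring carbon): methoxy in place of 4-hydroxypiperidin-1-yl on a saturated chain carbon bound to a saturated ring carbon.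

One measured step sits at that same place (a number 0.04 log units lower from compound 1 to compound 2 (within the scatter)) and exchanged hydroxy for 4-hydroxypiperidin-1-yl. The other step was large (a number 4.15 log units higher from compound 2 to compound 3 (beyond the scatter)), but it brought in 4-fluorophenyl on a saturated ring carbon, a different place, and bears only weakly here. Among the measured compounds shown here, no measured step brings in methoxy, which leaves the size uncertain. An expected step of a number 0.37 log units higher from compound 2 to compound 4 (beyond the scatter) is a cautious guess, small and upward in this assay. The estimated value for compound 4 is 2 (expected range 1.6 to 2.5).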

Compound 4, partition coefficient: 2.18
Compound 4: the middle estimate sits 0.18 log units below what was measured; the range from low to high includes it.
By their numbers in this assay, from the lowest: compounds 2 and 1 (each within the scatter of the next); then compound 4; then compound 3.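

In this assay, this place, on a saturated chain carbon bound to a saturated ring carbon, now shows a change that moves the number beyond the scatter: a number 0.55 log units higher from compound 2 to compound 4 (beyond the scatter), with methoxy in place of 4-hydroxypiperidin-1-yl. Methyl in place of hydrogen on the oxygen gives a similar step, a number 0.51 log units higher from compound 1 to compound 4 (beyond the scatter), while the much larger exchange of hydroxy for 4-hydroxypiperidin-1-yl gave only a number 0.04 log units lower from compound 1 to compound 2 (within the scatter), so among these three groups the number does not follow group size. Nothing shown here explains why this small methyl shifts the number when the larger group did not.

As far as these compounds go, whether a longer chain, such as ethoxy, would move the number further remains open. So does what a piperidin-1-yl group without the hydroxy, or a carboxylic acid, would do at this place.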